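A methoxy in place of chloro on the sulfonyl aryl ring

The compounds below may be only part of what the source reports. "The series", "measured", "known", "first", "only" and "open" are said of these compounds alone.

In an assay on isolated protein for inhibition of B1 bradykinin receptor (Homo sapiens) (a higher number here means a weaker inhibitor, a lower number a stronger inhibitor), three compounds have been measured so far:
compound 1, `CC(C)(C)NCc1ccc2c(c1)CCC[C@H]2NC(=O)C[C@@H]1CCCCN1S(=O)(=O)c1ccccc1`: 1700 nM
compound 2, `CCCCOc1ccc(S(=O)(=O)N2CCCC[C@H]2CC(=O)N[C@@H]2CCCc3cc(CNC(C)(C)C)ccc32)cc1`: 1200 nM
compound 3, `CC(C)(C)NCc1ccc2c(c1)CCC[C@H]2NC(=O)C[C@@H]1CCCCN1S(=O)(=O)c1ccc(Cl)cc1`: 560 nM

Compound 3 gives the lowest number of the three, and both gaps to it lie beyond the scatter: a 3.0-fold lower number from compound 1 to compound 3 (0.48 log units; beyond the scatter) and a 2.1-fold lower number from compound 2 to compound 3 (0.33 log units; beyond the scatter). Compound 1 and compound 2, by contrast, sit within the scatter of each other, as a 1.4-fold lower number from compound 1 to compound 2 (0.15 log units; within the scatter) shows.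

Compound 4, `COc1ccc(S(=O)(=O)N2CCCC[C@H]2CC(=O)N[C@@H]2CCCc3cc(CNC(C)(C)C)ccc32)cc1`, takes one further step away from compound 3: methoxy in place of chloro on an aromatic carbon. Among the compounds with values here, two measured steps bear on it. Hydrogen to chloro, a 3.0-fold lower number from compound 1 to compound 3 (0.48 log units; beyond the scatter), was a modest gain, and butoxy to chloro, a 2.1-fold lower number from compound 2 to compound 3 (0.33 log units; beyond the scatter), was a modest gain as well. Going from chloro to methoxy runs the second of these in reverse, with a shorter chain in place of butoxy, so a return toward the numbers of compound 1 and compound 2 is expected. Those two lie close together, a 1.4-fold lower number from compound 1 to compound 2 (0.15 log units; within the scatter), which gives no ground to place methoxy far from either of them. The expected step is a 2.3-fold higher number from compound 3 to compound 4 (0.37 log units; beyond the scatter), a higher number in this assay. The estimate for compound 4 in this assay is 1300 nM, with a range from 600 nM to 2800 nM.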

Compound 4, half-maximal inhibitory concentration: 780 nM
Compound 4: the middle estimate sits 1.7-fold (0.22 log units) above what was measured, and the stated range covers the measured number.
By their numbers in this assay, from the lowest: compounds 3, 4, 2 and 1 (each within the scatter of the next, the first and the last beyond it).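

In this assay, methoxy on this aromatic carbon, para to a large group, cannot be told apart from chloro, with a 1.4-fold higher number from compound 3 to compound 4 (0.14 log units; within the scatter). The gain over hydrogen therefore does not belong to chloro alone: a 2.2-fold lower number from compound 1 to compound 4 (0.34 log units; beyond the scatter) is a modest step of the same kind as a 3.0-fold lower number from compound 1 to compound 3 (0.48 log units; beyond the scatter), while butoxy, the only other oxygen-linked group shown, did not clear the scatter from hydrogen and so stands against any simple rule that an oxygen-linked group at this position helps. Cutting butoxy back to methoxy also leaves no readable difference, with a 1.5-fold lower number from compound 2 to compound 4 (0.19 log units; within the scatter), so compound 4 lies within the scatter of both compound 2 and compound 3 even though those two lie beyond it from each other, and nothing measured here accounts for these readings.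

Whether the intermediate ethoxy and propoxy chains would fall closer to methoxy or to butoxy remains open, and the small gaps among these compounds make any trend with chain length hard to judge. From the compounds shown here alone, it is also open how fluoro, a nitrile, an amine or a carboxylic acid would read on this same carbon.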